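Swapping 2-hydroxyethyl for 3-hydroxycyclobutyl in the series

The source may hold more compounds than are shown below. What is called first, only, known or untested is meant among the compounds shown, and "the series" means these compounds.

compound 1 `COc1cc(C(=O)N2CCC(O)C(C)C2)cn2nc(NCc3cccc(Cl)c3)nc12`: 35 mL/min/kg
compound 2 `COc1cc(C(=O)N2CC(C)OCC2CCO)cn2nc(NCc3cccc(Cl)c3)nc12`: 31.7 mL/min/kg

For the measured compounds named here, in an ADME assay on cells (Hepatocyte, Rattus norvegicus, strain Wistar) for pharmacokinetics, read by LC-MS, with a stated time of 90 min, tested at 1 uM (on this read-out higher numbers stand for fast clearance and lower numbers for slow clearance), compound 2 stands within the scatter of compound 1, the only other compound measured. Compound 3 `COc1cc(C(=O)N2CC(C)OCC2C2CC(O)C2)cn2nc(NCc3cccc(Cl)c3)nc12` differs from compound 2 by 3-hydroxycyclobutyl in place of 2-hydroxyethyl on a saturated ring carbon, with 3-hydroxycyclobutyl in place of 2-hydroxyethyl on a saturated ring carbon. Going by the values given here, the one measured step, a 1.1-fold lower number from compound 1 to compound 2 (0.04 log units; within the scatter), replaced the whole group on the carbonyl carbon and stayed within the scatter. Among the compounds with values here, no measured step tests the present replacement directly. No shift beyond the scatter is expected in this assay, and the estimated step is a 1.0-fold higher number from compound 2 to compound 3 (0.02 log units; within the scatter) in size. For compound 3 the estimated clearance is 33 mL/min/kg, with an expected range of 18 mL/min/kg to 58 mL/min/kg for the coming measurement.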

Compound 3, clearance: 50 mL/min/kg
Estimate against measurement, compound 3: 1.5-fold (0.18 log units) below, and the stated range covers the measured number.
By their numbers in this assay, from the lowest: compounds 2, 1 and 3 (each within the scatter of the next).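

For the compounds shown here, at the saturated ring carbon next to the ring nitrogen, 3-hydroxycyclobutyl in place of 2-hydroxyethyl gives a 1.6-fold higher number from compound 2 to compound 3 (0.20 log units; within the scatter) in this assay, the only reading here of a change at this position alone. A four-membered carbon ring bearing a hydroxyl thus stands in for the open chain without a step beyond the scatter. No evidence on the cause bears on this result.

Still open, from the compounds shown here alone, is whether an amine, a carboxylic acid or a longer hydroxyalkyl chain on this carbon would take clearance beyond the scatter in this assay. Unsubstituted cyclobutyl would show whether the hydroxyl on the ring matters at all.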